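Swapping One Ring Group on a Bromophenyl Compound

This account rests on a few compounds, and the source may have more. Where it says the series, first, only, none or still open, it means among the compounds named here.

In a functional assay on HepG2 cells (Homo sapiens) for inhibition, read by CCK-8 assay, with a stated time of 48 h (on this read-out higher numbers stand for weaker inhibition and lower numbers for stronger inhibition), compound 1 (`O=C1CSC(N2N=C(c3ccc(Cl)cc3)CC2c2cccc3ccccc23)=N1`) gives 16500 nM and compound 2 (`O=C1CSC(N2N=C(c3ccc(F)cc3)CC2c2cccc3ccccc23)=N1`) gives 19500 nM. Compound 3 (`Brc1ccc(C2=NN(C3=NC(c4ccccc4)CS3)C(c3cccc4ccccc34)C2)cc1`) gives 15600 nM, so it stands level with the other two, all three lying within the usual scatter of one another.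

Compound 4 (`O=C1CSC(N2N=C(c3ccc(Br)cc3)CC2c2cccc3ccccc23)=N1`) differs from compound 3 by one change on an amine nitrogen in a ring: a group of 6 heavy atoms (3 carbon, 1 nitrogen, 1 oxygen, 1 sulfur; one five-membered non-aromatic ring with 2 hetero atoms) in place of a group of 11 heavy atoms (9 carbon, 1 nitrogen, 1 sulfur; one five-membered non-aromatic ring with 2 hetero atoms, one six-membered aromatic ring of carbon only), on an amine nitrogen in a ring. It keeps the 4-bromophenyl group and takes on the group that compound 1 and compound 2 also carry.

For the measured compounds named here, no measured step covers this exchange directly. Going by the values given here, the one measured step, a 1.2-fold higher number from compound 1 to compound 2 (0.07 log units; within the scatter), is fluoro in place of chloro and stays within the scatter. Compound 1, with the entering group and chloro instead of bromo, gives 16500 nM, while compound 3, with the leaving group, gives 15600 nM. The expected step is therefore a 1.1-fold higher number from compound 3 to compound 4 (0.04 log units; within the scatter), nothing beyond the scatter. For compound 4 the estimate is 17000 nM, with an expected range from 10000 nM to 29000 nM.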

Compound 4, half-maximal inhibitory concentration: 13400 nM
Compound 4: the middle estimate sits 1.3-fold (0.10 log units) above what was measured, within the range that was stated.
By their numbers in this assay, from the lowest: compounds 4, 3, 1 and 2 (each within the scatter of the next).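

In this assay, the group of 6 heavy atoms in place of the group of 11 heavy atoms on the amine nitrogen gives a 1.2-fold lower number from compound 3 to compound 4 (0.07 log units; within the scatter), so with the 4-bromophenyl group kept, the six-membered aromatic ring on the leaving group can go without a change beyond the scatter. Bromo also reads level with the other two halogens on the aromatic ring, with a 1.5-fold lower number from compound 2 to compound 4 (0.16 log units; within the scatter) and a 1.2-fold lower number from compound 1 to compound 4 (0.09 log units; within the scatter) both lying within the scatter. No measurement on hand gives a reason for these readings.

All the compounds shown keep the naphthalen-1-yl group and a halogen on the phenyl ring, and both groups seen on the amine nitrogen hold a five-membered ring. Going by these compounds, whether a carboxylic acid or an open-chain amine at that nitrogen, or a methoxy group in place of the halogen, would move the number beyond the scatter stays open.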